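This account rests on a few compounds, and the source may have more. Where it says the series, first, only, none or still open, it means among the compounds named here.

In a functional assay on Jurkat cells (Homo sapiens) for inhibition (a lower number here means a stronger inhibitor, a higher number a weaker inhibitor), compound 1 `CC(C)[C@H](NC(=O)COc1cccc2ccccc12)C(=O)N[C@@H](CC(=O)O)C(=O)CSc1ncc[nH]1` gives only a limit, > 200000 nM. Compound 2 `CC(C)[C@H](NC(=O)COc1cccc2ccccc12)C(=O)N[C@@H](CC(=O)O)C(=O)CSc1nc(-c2ccccc2)c(-c2ccccc2)[nH]1` also gives only a limit, > 200000 nM. Compound 3 `CC(C)[C@H](NC(=O)COc1cccc2ccccc12)C(=O)N[C@@H](CC(=O)O)C(=O)CSc1nc(-c2ccccc2)c(-c2ccccc2)o1` likewise gives only a limit, > 200000 nM. Among the measured compounds shown here, every value shown thus sits at the limit of > 200000 nM in this assay, at which 3 of the 3 values shown sit, so compound 1 can be neither separated from nor ranked against the other two, and no step between measured compounds is known. Compound 4 `CC(C)[C@H](NC(=O)COc1cccc2ccccc12)C(=O)N[C@@H](CC(=O)O)C(=O)CSc1nnc(-c2ccccc2)o1` carries 5-phenyl-1,3,4-oxadiazol-2-yl in place of 1H-imidazol-2-yl on a sulfur, that is, 5-phenyl-1,3,4-oxadiazol-2-yl in place of 1H-imidazol-2-yl on a sulfur. Compounds 2 and 3 with other groups on the same sulfur remain at their limits, so no change beyond the scatter is expected, the estimated step being a step that the limit leaves unreadable from compound 1 to compound 4. Compound 4 is expected near 300000 nM, within a range from 120000 nM to 800000 nM, most probably reported in this assay only as a limit.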

Compound 4, half-maximal inhibitory concentration: 150000 nM
Beside the measured number, compound 4's estimate is 2.0-fold (0.30 log units) above it; low and high end bracket the measured number.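

In this assay compound 4 is the only compound shown with a number rather than a limit, so this group on the sulfur gives the series its first readable value. The change to 5-phenyl-1,3,4-oxadiazol-2-yl gives an at least 1.3-fold lower number from compound 1 to compound 4 (0.12 log units; that floor lies within the scatter) and so establishes no gain beyond the scatter. The other compounds stay at a limit: the limit of > 200000 nM in this assay, at which 3 of the 4 values shown sit. As far as these compounds go, it remains open whether an amine or a carboxylic acid on the phenyl ring of this group would shift the number, and whether a methyl group in place of that phenyl would still give a readable value.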